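The source may report more compounds than this note shows. Statements on the series, on what has been measured and on what is new or still open speak of the compounds shown alone.

Compound 1 `C=CCOc1ccc(C(=O)Nc2cccc(C)n2)cc1` is an amide built from a propenyloxy-substituted benzoyl part and an aminopyridine part. In an in vitro assay on HEK-tsA201 cells for antagonist activity at Neuronal acetylcholine receptor; alpha4/beta2 (Homo sapiens), read by fluorescence and calcium flux (a lower number here means a stronger inhibitor, a higher number a weaker inhibitor), compound 1 gives 6000 nM. Compound 2 `C=CCOc1ccc(C(=O)Nc2cccc(CC)n2)cc1` carries the change (methyl in place of hydrogen on a saturated chain carbon bound to an aromatic carbon), and in this assay compound 2 gives 20500 nM, so the step of a 3.4-fold higher number from compound 1 to compound 2 (0.53 log units; beyond the scatter) reads as a loss of potency that is clearly outside routine noise.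

Compound 3 `CCCNc1cccc(NC(=O)c2ccc(OCCC)cc2)n1` belongs to a different core from compound 1; the difference between the two cores is not broken down here. In this assay compound 3 gives 15400 nM, which sits close to compound 2 and is weaker than compound 1.

Compound 4 `CCCCNc1cccc(NC(=O)c2ccc(OCCC)cc2)n1` has not yet been measured. Relative to compound 3 it carries methyl in place of hydrogen on a saturated chain carbon, three bonds along the chain from a nitrogen on an aromatic ring. Going by the values given here, this is the same kind of change as the one from compound 1 to compound 2, but not the same: there the methyl entered on a saturated chain carbon bound to an aromatic carbon, whereas here it enters on a saturated chain carbon, three bonds along the chain from a nitrogen on an aromatic ring, that is, further out along an existing chain.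

Because the earlier step of a 3.4-fold higher number from compound 1 to compound 2 (0.53 log units; beyond the scatter) made the number higher, a move in the same direction is expected for compound 4, but smaller, since the added carbon sits further from the ring; the expected step is a 1.6-fold higher number from compound 3 to compound 4 (0.21 log units; within the scatter). Compound 4 is therefore estimated at 25000 nM, with a likely range from 10000 nM to 60000 nM.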

Compound 4, half-maximal inhibitory concentration: 54100 nM
Estimate against measurement, compound 4: 2.2-fold (0.34 log units) below; measured number inside the range.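

In this assay, going from a propyl to a butyl chain on the nitrogen gives a 3.5-fold higher number from compound 3 to compound 4 (0.55 log units; beyond the scatter), a loss of potency that closely matches the step seen on the other core: the same change on two cores in this assay, a 3.4-fold higher number (0.53 log units; beyond the scatter) from compound 1 to compound 2 and a 3.5-fold higher number (0.55 log units; beyond the scatter) from compound 3 to compound 4, 1.0-fold (0.01 log units) apart, within the scatter of two such steps

Within these two pairs, then, one added methyl on a saturated chain carbon raises the number by a similar amount on both cores, even though it enters at a different place in each: on a chain carbon bound to an aromatic carbon in compound 2, and three bonds along the chain from a nitrogen on an aromatic ring in compound 4. Going by these compounds alone, this is only two pairs in one assay, so it supports carrying the change between these two cores but does not establish a rule for other cores or other chain positions, and it does not explain why the number rises.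

On these data alone, what a pentyl or other longer chain would do on the core of compound 3 remains open, as does whether the number would keep rising. Also open, as far as these compounds go, is how a branched chain, or a chain ending in a hydroxyl group or an amine, would compare with the butyl chain of compound 4.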